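Cyclopropylcarbonyl in place of acetyl on a second core

The source may report more compounds than this note shows. Statements on the series, on what has been measured and on what is new or still open speak of the compounds shown alone.

Compound 1 `CC(=O)Nc1n[nH]c2cc(-c3cn([C@@H]4CN[C@H](C(=O)Nc5ccc(Cl)cc5Cl)C4)nn3)ccc12` carries an acetamido group on its core and, in a functional assay on K562 cells (Homo sapiens) for inhibition, read by MTT assay, with a stated time of 48 h (a lower number here means a stronger inhibitor, a higher number a weaker inhibitor), compound 1 gives 2090 nM. Compound 2 `O=C(Nc1n[nH]c2cc(-c3cn([C@@H]4CN[C@H](C(=O)Nc5ccc(Cl)cc5Cl)C4)nn3)ccc12)C1CC1` keeps everything else and replaces the acetyl by a cyclopropylcarbonyl; the change cyclopropyl in place of methyl on a carbonyl carbon makes a 2.6-fold higher number from compound 1 to compound 2 (0.41 log units; beyond the scatter). In this assay compound 2 gives 5340 nM.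

Compound 3 `CC(=O)Nc1nc2ccc(-c3cn([C@@H]4CN[C@H](C(=O)Nc5ccc(Cl)cc5Cl)C4)nn3)nc2s1` has a different core bearing the same acetamido group and the same triazole-linked pyrrolidine amide. The difference between the core of compound 3 and the core of compound 1 is not broken down here. In this assay compound 3 gives 9670 nM, the highest of the three numbers; against compound 2 the gap is within the scatter, against compound 1 it is beyond it.

Compound 4 `O=C(Nc1nc2ccc(-c3cn([C@@H]4CN[C@H](C(=O)Nc5ccc(Cl)cc5Cl)C4)nn3)nc2s1)C1CC1` is compound 3 with the change (cyclopropyl in place of methyl on a carbonyl carbon), the same change, at the same place, as that from compound 1 to compound 2. Going by the values given here, only one earlier instance of this change is available, so a guide this thin is taken with caution. The step from compound 3 to compound 4 is expected to resemble that from compound 1 to compound 2, and is estimated as a 2.4-fold higher number from compound 3 to compound 4 (0.38 log units; beyond the scatter), because compound 1 to compound 2 showed a 2.6-fold higher number from compound 1 to compound 2 (0.41 log units; beyond the scatter). Compound 4 is therefore expected to give about 23000 nM in this assay, with a range from 9000 nM to 60000 nM.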

Compound 4, half-maximal inhibitory concentration: 740 nM
The estimate for compound 4 lay 31-fold (1.49 log units) above the measured number; the whole stated range lies above it.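

In this assay, cyclopropyl in place of methyl on a carbonyl carbon gives a 13-fold lower number from compound 3 to compound 4 (1.12 log units; beyond the scatter), a large step in the opposite direction to the one seen with the same change on the core of compound 1. The effect of this change therefore does not carry over from one core to the other in this series, in either direction or size, and a step measured on one core is a poor guide to the step on the other: the same change on two cores in this assay, a 2.6-fold higher number (0.41 log units; beyond the scatter) from compound 1 to compound 2 and a 13-fold lower number (1.12 log units; beyond the scatter) from compound 3 to compound 4, 33-fold (1.52 log units) apart, beyond the scatter of two such steps This shows that the outcome of the change depends on the core it is made on, but it does not show which feature of the cores is responsible, and with one matched pair per core it gives no general rule for any further core.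

Open, as far as these compounds go, is whether propionyl or cyclobutylcarbonyl in place of the cyclopropylcarbonyl of compound 4 would keep the lower number on this core, and whether either would raise the number on the core of compound 1, as cyclopropylcarbonyl does there. Also open, from the compounds shown here alone, is how a free amine in place of the acetamido group would read on each core, and whether a third core would follow either pattern.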